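A few compounds are considered here, and "the series" means these few. Any claim that something is new, unique, unknown or untested is made for them only; others in the source may bear on it.

Measured so far:
compound 1 `Cc1nc2c3ccccc3ccc2c2nc3c(ccc4ccccc43)c(-c3cccc([N+](=O)[O-])c3)c12` gives 157 ug/mL
compound 2 `Cc1ccc(-c2c3ccc4ccccc4c3nc3c2c(C)nc2c4ccccc4ccc32)cc1` gives 192 ug/mL

Both numbers come from a functional assay, with a stated time of 90 s; a lower number here means a stronger inhibitor, a higher number a weaker inhibitor. Within the data shown here, compound 1 has the lower of the two numbers, yet its only neighbour, compound 2, sits so close that the step of a 1.2-fold higher number from compound 1 to compound 2 (0.09 log units; within the scatter) does not separate them; neither can be called the stronger inhibitor on this evidence. Compound 3 `Cc1nc2c3ccccc3ccc2c2nc3c(ccc4ccccc43)c(-c3cc(O)nc4ccccc34)c12` has not yet been tested. It differs from compound 1 in one place: 2-hydroxyquinolin-4-yl in place of 3-nitrophenyl on an aromatic carbon. Among the measured compounds shown here, the single measured step, which put 4-methylphenyl in place of 3-nitrophenyl at the same position, stayed within the scatter, so a swap of the group at this place has so far not moved the number. That step does not involve the entering group, and nothing measured speaks to it directly. The estimate for compound 3 is therefore a number close to that of compound 1, with the step of a 1.0-fold higher number from compound 1 to compound 3 (0.01 log units; within the scatter) expected to stay within the scatter. Compound 3 is expected to give 160 ug/mL, between 80 ug/mL and 320 ug/mL.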

Compound 3, half-maximal inhibitory concentration: 148 ug/mL
For compound 3 the middle estimate is 1.1-fold (0.03 log units) above the measured one; measured number inside the range.
By their numbers in this assay, from the lowest: compounds 3, 1 and 2 (each within the scatter of the next).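

In this assay, putting 2-hydroxyquinolin-4-yl in place of 3-nitrophenyl gives a 1.1-fold lower number from compound 1 to compound 3 (0.03 log units; within the scatter), and putting it in place of 4-methylphenyl gives a 1.3-fold lower number from compound 2 to compound 3 (0.11 log units; within the scatter). This aromatic carbon, opposite the ring nitrogen, has now carried three different groups with no step beyond the scatter. Among these compounds, the earlier step compared only two groups with a single aromatic ring, whereas the entering group has two aromatic rings, more heavy atoms and a hydrogen-bond donor, and the number still does not separate from the others.

All three groups shown are aromatic, and how an amine, a carboxylic acid or a longer alkyl chain at this position would read in this assay remains open. Nothing measured here says why the number holds steady across these groups.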